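A few compounds are considered here, and "the series" means these few. Any claim that something is new, unique, unknown or untested is made for them only; others in the source may bear on it.

Three thiosemicarbazones sharing one core have been measured in an ADME assay on RAW264.7 cells (Mus musculus) for cytotoxicity, read by MTT assay, with a stated time of 48 h; a higher number here means that more compound is tolerated, a lower number that less compound is tolerated. Compound 1 `COc1ccc(NC(=S)N/N=C\c2ccnc3ccccc23)cc1` gives 101000 nM, the highest number of the three. Compound 2 `S=C(N/N=C\c1ccnc2ccccc12)Nc1cccnc1` gives 91600 nM, and compound 3 `Fc1ccc(NC(=S)N/N=C\c2ccnc3ccccc23)cc1` gives 45900 nM. The change from compound 1 to compound 2 is a 1.1-fold lower number from compound 1 to compound 2 (0.04 log units; within the scatter), so these two compounds cannot be told apart here. Compound 3, however, stands beyond the scatter from compound 1: a 2.2-fold lower number from compound 1 to compound 3 (0.34 log units; beyond the scatter), a modest step. From compound 2 to compound 3 the number moves as a 2.0-fold lower number from compound 2 to compound 3 (0.30 log units; within the scatter).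

Compound 4 `O=[N+]([O-])c1ccc(NC(=S)N/N=C\c2ccnc3ccccc23)cc1` differs from compound 1 in one place: nitro in place of methoxy on an aromatic carbon. Within the data shown here, the step that bears on it most closely is the one from compound 1 to compound 3, since there too one group was exchanged for another on the same aromatic carbon, and that exchange lowered the number modestly. The exchange of the group on the amide-type nitrogen, from compound 1 to compound 2, gave no step beyond the scatter. He therefore expects compound 4 to sit somewhat below compound 1, the step being roughly a 1.8-fold lower number from compound 1 to compound 4 (0.26 log units; within the scatter), a lowering that could still fall inside the scatter. His estimate for compound 4 in this assay is 55000 nM, expected to lie between 25000 nM and 110000 nM.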

Compound 4, half-maximal cytotoxic concentration: 82500 nM
Beside the measured number, compound 4's estimate is 1.5-fold (0.18 log units) below it; the range from low to high includes it.
By their numbers in this assay, from the lowest: compounds 3, 4, 2 and 1 (each within the scatter of the next, the first and the last beyond it).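

In this assay, among these compounds, the exchange of methoxy for nitro on this aromatic carbon, para to a large group, gives no step that can be told from the scatter (a 1.2-fold lower number from compound 1 to compound 4 (0.09 log units; within the scatter)), so this position accepts a group with more heavy atoms and more hydrogen-bond acceptors, and no net charge, without a clear change in the number. Among the compounds shown here, compound 4 cannot be separated from compound 3 either (a 1.8-fold higher number from compound 3 to compound 4 (0.25 log units; within the scatter)), so although the fluoro group of compound 3 is the only exchange here that stands beyond the scatter from compound 1, nitro does not show that the fluoro result is special to fluoro, and the three groups give no firm order among them. Nothing available here explains how the number responds to these exchanges.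

The compounds shown leave open whether an amine or a carboxylic acid on this aromatic carbon, or a longer chain such as butoxy in place of methoxy, would move the number clearly away from compound 1. They also leave open whether nitro would behave in the same way at another place on this ring.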